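The compounds below may be only part of what the source reports. "The series", "measured", "known", "first", "only" and "open" are said of these compounds alone.

Compound 1, `Cc1nc(S(C)(=O)=O)ccc1Oc1ncnc(OC2CCN(C(=O)O[C@H](C)C(F)(F)F)CC2)c1F`, gives 85%.
Compound 2, `Cc1nc(S(C)(=O)=O)ccc1Oc1ncnc(OC2CCN(C(=O)OC3(C(F)(F)F)CCC3)CC2)c1F`, gives 82%.
Compound 3, `Cc1nc(S(C)(=O)=O)ccc1Oc1ncnc(OC2CCN(C(=O)SC(C)(C)C)CC2)c1F`, gives 76%.

All three numbers come from a functional assay on isolated protein for inhibition of Glucose-dependent insulinotropic receptor (Rattus norvegicus), read by HTRF and cAMP accumulation; on this read-out higher numbers stand for larger maximal responses and lower numbers for smaller maximal responses. Compound 3 has the lowest of the three numbers, but its distance to each neighbour is small: a number 9 percentage points lower from compound 1 to compound 3 (within the scatter) and a number 6 percentage points lower from compound 2 to compound 3 (within the scatter), so the three compounds cannot be told apart on this read-out. Compound 4, `Cc1nc(S(C)(=O)=O)ccc1Oc1ncnc(OC2CCN(C(=O)SC3CCC3)CC2)c1F`, has not been measured. It differs from compound 3 in one place: cyclobutyl in place of tert-butyl on a sulfur. Going by the values given here, the most comparable measured step is the one from compound 1 to compound 2, where an open chain on the oxygen was likewise replaced by a four-membered ring: a number 3 percentage points lower from compound 1 to compound 2 (within the scatter). Since that step, and every other step here, stayed within the scatter, no step beyond the scatter is expected in this assay for compound 4 either. The expected step is a number 2 percentage points higher from compound 3 to compound 4 (within the scatter). Compound 4 is therefore estimated at 78%, with a range from 66% to 90%.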

Compound 4, largest response reached (reported as efficacy), in percent of the reference or control that the assay uses: 81%
The estimate for compound 4 lay 3 percentage points below the measured number; the range from low to high includes it.
By their numbers in this assay, from the lowest: compounds 3, 4, 2 and 1 (each within the scatter of the next).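

On the sulfur whose other neighbour is the carbonyl carbon, the ring of cyclobutyl can take the place of the open tert-butyl with no change that can be told apart in this assay: a number 5 percentage points higher from compound 3 to compound 4 (within the scatter). The wider exchange of the whole group on the carbonyl carbon also stays unresolved, with cyclobutylsulfanyl replacing the group in one case and 1-(trifluoromethyl)ethoxy in the other: a number 1 percentage points lower from compound 2 to compound 4 (within the scatter), and a number 4 percentage points lower from compound 1 to compound 4 (within the scatter). No measurement is available that could explain these results.

The compounds shown leave open whether an amine on the carbonyl carbon, or a longer chain such as hexyl on the sulfur, would produce a step beyond the scatter. They also say nothing about how much compound is needed to reach these maximal responses.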